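A few compounds are considered here, and "the series" means these few. Any claim that something is new, unique, unknown or untested is made for them only; others in the source may bear on it.

Measured so far:
- compound 1, `COc1cc(OC)c(C(=O)/C=C/c2ccc(Cl)cc2)c(OC)c1`: 1.5%
- compound 2, `COc1cc(O)c(C(=O)/C=C/c2ccccc2SC)c(OC)c1`: 37%

Working notes on the series. Among the measured compounds shown here, in a functional assay on Caco-2 cells (Homo sapiens), read by fluorescence and BrdU incorporation, with a stated time of 48 h, tested at 25 uM (on this read-out lower numbers stand for a stronger effect and higher numbers for a weaker effect at the one concentration tested), compound 1 gives 1.5%, the lowest of the two numbers known and so the stronger effect; compound 2 gives 37%, a number far higher and beyond the scatter. Compound 2 differs from compound 1 in more than one place, so no single step can be read from that pair; the two values are noted only for what they show.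

Compound 3, `COc1cc(OC)c(C(=O)/C=C/c2ccccc2)c(OC)c1`, is still to be measured in this assay. It differs from compound 1 in one place: hydrogen in place of chloro on an aromatic carbon. Only compound 1 carries the chloro group among the measured compounds, and nothing in the data isolates the contribution of that group. The expectation for the step of a number 13.5 percentage points higher from compound 1 to compound 3 (beyond the scatter) is a modest rise toward a weaker effect, with a fair chance that it stays within the scatter. Compound 3 is therefore estimated at 15%, in a range from 2% to 45%.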

Compound 3, a percentage reported as activity, at one concentration (the size of the read-out at that concentration, not a potency): 24%
Compound 3: the middle estimate sits 9 percentage points below what was measured, and the stated range covers the measured number.
By their numbers in this assay, from the lowest: compound 1; then compound 3; then compound 2.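

In this assay, the exchange of chloro for hydrogen on an aromatic carbon, para to a large group, can now be read as a single change with the rest of the structure held constant: it gives a number 22.5 percentage points higher from compound 1 to compound 3 (beyond the scatter). Before this pair, the role of the chloro group could not be separated from the other differences in the series; now 4-chlorophenyl is linked to the stronger effect and phenyl to the weaker one, at the one concentration tested and for this one pair. No measurement at hand bears on what lies behind this step, so only its size and direction can be stated.

On these data alone, it remains open whether this step is particular to chloro or would also appear with another group in the same place, such as fluoro, bromo, methoxy or an amine. It also remains open whether the step would keep its size on a different core, and a reading at one concentration gives no potency for any of these compounds.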